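This account rests on a few compounds, and the source may have more. Where it says the series, first, only, none or still open, it means among the compounds named here.

The study concerns four compounds that share a core in which a five-membered non-aromatic ring with one nitrogen and one sulfur carries an aryl group on its amide-type nitrogen. Compound 1 has the structure `COc1ccccc1N1C(=O)/C(=C/c2ccc(OCc3ccc(C(=O)O)cc3)cc2)SC1=S` and compound 2 the structure `COc1ccccc1N1C(=O)/C(=C/c2cccc(OCc3ccc(C(=O)O)cc3)c2)SC1=S`; the two are built from the same atoms joined differently, and the difference between the two cores is not broken down here. In an assay on isolated protein for inhibition of Apoptosis regulator Bcl-2 (Homo sapiens), read by fluorescence polarization (on this read-out higher numbers stand for weaker inhibition and lower numbers for stronger inhibition), compound 1 gives 2000 nM. In this assay compound 2 gives 1600 nM, a value within the scatter of that of compound 1.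

Compound 3, with structure `O=C(O)c1ccc(COc2ccc(/C=C3\SC(=S)N(c4ccc([N+](=O)[O-])cc4)C3=O)cc2)cc1`, differs from compound 1 by 4-nitrophenyl in place of 2-methoxyphenyl on an amide-type nitrogen in a ring. For compound 3 this assay reports only a limit, > 10000 nM. The resulting step is an at least 5.0-fold higher number from compound 1 to compound 3 (0.69 log units; beyond the scatter), and its size is bounded only because of the limit of > 10000 nM in this assay, at which 1 of the 3 values shown sits.

Compound 4, with structure `O=C(O)c1ccc(COc2cccc(/C=C3\SC(=S)N(c4ccc([N+](=O)[O-])cc4)C3=O)c2)cc1`, has not yet been measured in this assay. It differs from compound 2 by 4-nitrophenyl in place of 2-methoxyphenyl on an amide-type nitrogen in a ring, the same change that turns compound 1 into compound 3, made at the same place on the ring.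

Among the measured compounds shown here, the expected step of a 9.4-fold higher number from compound 2 to compound 4 (0.97 log units; beyond the scatter) rests on the single measured instance of this change, the step of an at least 5.0-fold higher number from compound 1 to compound 3 (0.69 log units; beyond the scatter), and is therefore expected to be of at least that size. Compound 4 is accordingly estimated at 15000 nM in this assay, with a likely range from 6000 nM to 40000 nM, and a fair chance that only a limit is reported.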

Compound 4, inhibition constant: > 10000 nM
Compound 4: no number, only a limit; the forecaster's own chance of this, stated with the estimate: 65%; the middle value does not contradict the limit.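

In this assay, 4-nitrophenyl in place of 2-methoxyphenyl on the amide-type nitrogen in the ring gives an at least 6.2-fold higher number from compound 2 to compound 4 (0.79 log units; beyond the scatter). The change therefore goes in the same direction on the core of compound 2 as on the core of compound 1, towards weaker inhibition and beyond the scatter on both, so within these four compounds its direction carries over from one core to the other: the same change on two cores in this assay, an at least 5.0-fold higher number (0.69 log units; beyond the scatter) from compound 1 to compound 3 and an at least 6.2-fold higher number (0.79 log units; beyond the scatter) from compound 2 to compound 4; the limit leaves it open whether they differ What this does not show is how large the change truly is on either core, or whether the two cores respond to it equally, because compound 3 and compound 4 are each reported only as a limit and both steps are bounded on one side alone: the limit of > 10000 nM in this assay, at which 2 of the 4 values shown sit.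

The compounds shown leave open whether the weakening belongs to the 4-nitrophenyl group in particular or would also appear with a plain phenyl, a 4-methoxyphenyl or a 2-chlorophenyl group on the same nitrogen, as only two aryl groups stand there among these compounds. They also leave open how the series would read with an amine or a tetrazole in place of the carboxylic acid that all four compounds carry.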